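The source may report more compounds than this note shows. Statements on the series, on what has been measured and on what is new or still open speak of the compounds shown alone.

In a functional assay on HCT-116 cells (Homo sapiens) for antiproliferative activity, read by sulforhodamine B assay, with a stated time of 72 h (on this read-out lower numbers stand for stronger inhibition and higher numbers for weaker inhibition), compound 1 `CC(C)[C@@H](O)[C@H](O)C(=O)NS(=O)(=O)OC[C@H]1O[C@@H](n2cnc3c(N)ncnc32)C[C@@H]1O` gives 6520 nM. Compound 2 `CC(C)C[C@H](O)C(=O)NS(=O)(=O)OC[C@H]1O[C@@H](n2cnc3c(N)ncnc32)[C@H](O)[C@@H]1O`, in this assay, gives 3470 nM; the gap between compound 2 and compound 1 is within the scatter of repeated measurements, so neither compound stands apart from the other on these two numbers. Compound 3 `CC(C)C[C@H](O)C(=O)NS(=O)(=O)OC[C@H]1O[C@@H](n2cnc3c(=O)[nH]cnc32)[C@H](O)[C@@H]1O` has not yet been measured. It differs from compound 2 in one place: a group of 10 heavy atoms (5 carbon, 4 nitrogen, 1 oxygen; one five-membered aromatic ring with 2 hetero atoms, one six-membered aromatic ring with 2 hetero atoms) in place of a group of 10 heavy atoms (5 carbon, 5 nitrogen; one five-membered aromatic ring with 2 hetero atoms, one six-membered aromatic ring with 2 hetero atoms), on a saturated ring carbon. For the measured compounds named here, no measured pair in this set shows the same change, so nothing here tells how large such a step is. Taken on its own, the step is expected to move the number upward, that is toward weaker inhibition, beyond the scatter; the expected step of a 4.3-fold higher number from compound 2 to compound 3 (0.64 log units; beyond the scatter) reflects this. On that basis compound 3 is expected to give about 15000 nM in this assay, with a plausible range from 5000 nM to 60000 nM.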

Compound 3, half-maximal inhibitory concentration: > 20000 nM
Compound 3: only a limit was reported; the forecaster's own chance of this, stated with the estimate: 15%; middle value at least 1.3-fold (0.12 log units) away from the limit.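

In this assay the entry for compound 3, > 20000 nM, is a limit of the assay and not a number. Placing the group of 5 carbon, 4 nitrogen and 1 oxygen atoms on the saturated ring carbon next to the ring oxygen, instead of the group of 5 carbon and 5 nitrogen atoms, gives an at least 5.7-fold higher number from compound 2 to compound 3 (0.76 log units; beyond the scatter), so activity here responds to a change at this position, which the two earlier values, within the scatter of each other, could not show. The step has only a lower bound, and its full size stays unknown: the limit of > 20000 nM in this assay, at which 1 of the 3 values shown sits.

The compounds shown leave open how a methylamino group or a chlorine atom in place of the carbonyl oxygen would behave in this assay. They also leave open whether the same change on the core of compound 1 would give a step of similar size.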